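The compounds below may be only part of what the source reports. "The series", "measured", "known", "first", "only" and "open" are said of these compounds alone.

Of the compounds shown here, two have been measured in an assay on NIH3T3 cells with Urotensin-2 receptor (Homo sapiens) as the target; a lower number here means that less compound is needed, a higher number that more compound is needed for the effect. Compound 1 `COc1cccc(C(=O)OC(CCN(C)C)c2ccc(Cl)cc2)c1C` is one of them, and in this assay compound 1 gives 1950 nM. Compound 2 `COc1ccc(C(=O)NC(CCN(C)C)c2ccc(Cl)cc2)cc1` is the other, and in this assay compound 2 gives 1350 nM. Compound 2 stands nearest to compound 1, and the gap between the two numbers lies within the usual scatter of repeated measurements, so neither can be called the more potent of the pair. Compound 3 `CN(C)CCC(NC(=O)c1ccccc1)c1ccc(Cl)cc1` is the next compound, and it differs from compound 2 in one place: hydrogen in place of methoxy on an aromatic carbon. For the measured compounds named here, no pair of measured compounds shows what this change does on its own, so there is nothing to lean on but the two numbers already known. The change is expected to move the number only a little, a 1.3-fold higher number from compound 2 to compound 3 (0.12 log units; within the scatter), with no clear direction beyond the scatter. For compound 3 the expected value is 1800 nM, in a range from 700 nM to 5000 nM.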

Compound 3, half-maximal effective concentration: 1410 nM
The estimate for compound 3 lay 1.3-fold (0.11 log units) above the measured number; measured number inside the range.
By their numbers in this assay, from the lowest: compounds 2, 3 and 1 (each within the scatter of the next).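

Going from 4-methoxyphenyl to phenyl gives a 1.0-fold higher number from compound 2 to compound 3 (0.02 log units; within the scatter) in this assay so compound 2 and compound 3 cannot be told apart. For the compounds shown here, this is the first comparison here of two compounds that differ in one place, and it shows that, on this aromatic carbon para to a large group, the methoxy group is not needed to reach the number seen for this pair. No measurement is available that would explain this result.

Going by these compounds, it remains open whether a different group on this carbon, such as a chlorine atom, an amine or a carboxylic acid, would also leave the number within the scatter or would shift it clearly. On these data alone, the effect of replacing the amide link or the dimethylamino group, each on its own, also remains open.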